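Swapping the Amide Aryl Group for a Thiophene

The source may hold more compounds than are shown below. What is called first, only, known or untested is meant among the compounds shown, and "the series" means these compounds.

Compound 2 `Cc1cccc(C(=O)Nc2cc(-c3ccccc3)nn2-c2ccccc2)c1` gives 100 nM in an assay on isolated protein with metabotropic glutamate receptor 5 (Rattus norvegicus) as the target (a lower number here means that less compound is needed, a higher number that more compound is needed for the effect), the higher of the two numbers recorded; compound 1 `O=C(Nc1cc(-c2ccccc2)nn1-c1ccccc1)c1ccc(F)c(F)c1` gives 20 nM. Within the data shown here, the only step at the carbonyl carbon, a 5.0-fold higher number from compound 1 to compound 2 (0.70 log units; beyond the scatter), shows that the group there matters. Compound 3 `O=C(Nc1cc(-c2ccccc2)nn1-c1ccccc1)c1ccsc1` carries thiophen-3-yl in place of 3-methylphenyl on a carbonyl carbon. Among the measured compounds shown here, no measured step covers this exchange, so the expectation rests loosely on the sensitivity seen at that position. Compound 3 is expected to stay close to compound 2, with a step of a 1.3-fold lower number from compound 2 to compound 3 (0.10 log units; within the scatter), within the scatter. The estimate for compound 3 is 80 nM, ranging from 20 nM to 320 nM.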

Compound 3, half-maximal effective concentration: 2900 nM
For compound 3 the middle estimate is 36-fold (1.56 log units) below the measured one; measured number above the stated range.
By their numbers in this assay, from the lowest: compound 1; then compound 2; then compound 3.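

In this assay the carbonyl carbon proves far less tolerant than the earlier pair suggested: thiophen-3-yl in place of 3-methylphenyl gives a 29-fold higher number from compound 2 to compound 3 (1.46 log units; beyond the scatter) and so exceeds the step between the two substituted phenyl groups. Measured against 3,4-difluorophenyl, the same exchange gives a 150-fold higher number from compound 1 to compound 3 (2.16 log units; beyond the scatter) and is larger still. No evidence in hand explains this loss.

As far as these compounds go, it remains open whether the loss follows from the thiophene ring itself or from the absence of a substituent on it. An unsubstituted phenyl, a thiophen-2-yl or a methylthiophene on the carbonyl carbon would separate these readings.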